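A few compounds are considered here, and "the series" means these few. Any claim that something is new, unique, unknown or untested is made for them only; others in the source may bear on it.

Working notes on the series. Of the compounds shown here, three have been measured in a functional assay on A-375 cells (Homo sapiens) for inhibition, read by CCK-8 assay, with a stated time of 72 h, tested at 2 uM; on this read-out higher numbers stand for more inhibition of growth at the one concentration tested and lower numbers for less inhibition of growth. Compound 1 `Nc1ccccc1NC(=O)c1ccc(CSc2nccc(C(F)(F)F)n2)cc1` gives 54.4% in this assay, and compound 3 `Cc1cc(C)cc(SCc2ccc(C(=O)Nc3ccccc3N)cc2)c1` gives 48.5%. Compound 2 `Nc1ccccc1NC(=O)/C=C/c1ccc(CSc2ccc(Cl)cc2)cc1` gives 13.4%, the lowest of the three numbers; the gap to compound 3 and the larger gap to compound 1 both lie beyond the scatter. No pair among these three differs in a single place, so no step between measured compounds can be read from them, and the differences between compound 2 and the other two are only noted as they stand.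

Compound 4 `Nc1ccccc1NC(=O)/C=C/c1ccc(CSCCc2ccccc2)cc1` is not yet measured. It differs from compound 2 in one place: phenethyl in place of 4-chlorophenyl on a sulfur. Nothing in the measured set shows how a change at this sulfur moves the read-out. Taking compound 2 as the anchor, the expected step of a number 2.6 percentage points higher from compound 2 to compound 4 (within the scatter) is small and not beyond the scatter, in either direction. Compound 4 is therefore estimated at 16%, with a range from 2% to 38%.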

Compound 4, percent growth inhibition at one concentration: 41.9%
Estimate against measurement, compound 4: 25.9 percentage points below, outside the stated range (above it).
By their numbers in this assay, from the lowest: compound 2; then compounds 4, 3 and 1 (each within the scatter of the next, the first and the last beyond it).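

For the compounds shown here, this is the first step that can be read at a single place: on this sulfur in this assay, phenethyl in place of 4-chlorophenyl gives a number 28.5 percentage points higher from compound 2 to compound 4 (beyond the scatter). The read-out therefore responds to the group at this position while the rest of the structure stays the same. Both groups carry one six-membered aromatic ring of carbon only and no hydrogen-bond donors or acceptors, so those counts do not separate them, and no measurement at hand accounts for the step.

The compounds shown do not tell whether the step follows the loss of the chlorine or the arrival of the chain, a separation that unsubstituted phenyl or 4-chlorophenethyl on the same sulfur could provide. Also open, on these data alone, is how a longer chain, or a terminal amine or carboxylic acid, would behave at this position.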